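Lengthening the chain on the shared core

This account rests on a few compounds, and the source may have more. Where it says the series, first, only, none or still open, it means among the compounds named here.

Compound 2 `CCCCCCc1cc2cn(COCCO)c(O)nc-2n1` gives in a functional assay on HEL cells (Homo sapiens), read by microscopy (a lower number here means that less compound is tolerated, a higher number that more compound is tolerated), only a limit, > 400000 nM. Compound 3 `OCCOCn1cc2ccnc-2nc1O` likewise stops at a limit, > 400000 nM. Compound 1 `CCCCCCCCCc1cc2cn(COCCO)c(O)nc-2n1` also reaches only a limit, > 80000 nM. The step that the two limits leave unreadable from compound 2 to compound 3 cannot be read because the limit of > 400000 nM in this assay, at which 2 of the 3 values shown sit, hides any difference. The step that the two limits leave unreadable from compound 1 to compound 2 is unreadable because the limit of > 80000 nM in this assay, at which 1 of the 3 values shown sits, blocks the comparison. Compound 4 `CCCCCCCCCCc1cc2cn(COCCO)c(O)nc-2n1` differs from compound 2 by butyl in place of hydrogen on a saturated chain carbon, six bonds along the chain from an aromatic carbon. Neither measured step bears readably on this change, so the data give no direction and no size for it. Compound 4 is expected to stand at about 100000 nM, between 40000 nM and 400000 nM, and most probably to be reported again as a limit. The expected step is an at least 4.0-fold lower number from compound 2 to compound 4 (0.60 log units; beyond the scatter).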

Compound 4, minimum cytotoxic concentration: 80000 nM
Compound 4: the middle estimate sits 1.3-fold (0.10 log units) above what was measured; measured number inside the range.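

In this assay, within the data shown here, the butyl change gives an at least 5.0-fold lower number from compound 2 to compound 4 (0.69 log units; beyond the scatter), the first readable step at this position, on a saturated chain carbon, six bonds along the chain from an aromatic carbon. Compound 4 is also the only compound shown with a value that is a number and not a limit, and methyl in place of hydrogen on a saturated chain carbon, nine bonds along the chain from an aromatic carbon, gives a number no higher from compound 1 to compound 4 (the limit leaves the size open). The size of this step cannot be read: the limit of > 80000 nM in this assay, at which 1 of the 4 values shown sits.

The compounds shown leave open how far the number would fall with compound 2 measured exactly. They also leave open what a longer chain, or an amine in place of butyl, would give.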